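The compounds below may be only part of what the source reports. "The series", "measured", "known", "first", "only" and "open" are said of these compounds alone.

Three compounds have numbers in a functional assay on HEK293 cells for antagonist activity at metabotropic glutamate receptor 5 (Rattus norvegicus), read by calcium flux; a higher number here means a weaker inhibitor, a lower number a stronger inhibitor. Compound 1 `Cc1nc(C#Cc2cc(F)cc([N+](=O)[O-])c2)cs1` gives 0.61 nM, compound 2 `N#Cc1cc(C#Cc2ccccn2)cc([N+](=O)[O-])c1` gives 1.32 nM, and compound 3 `O=[N+]([O-])c1cc(Br)cc(C#Cc2ccccn2)c1` gives 0.39 nM. Of these three, compound 3 lies within the scatter of compound 1, while the step of a 3.4-fold lower number from compound 2 to compound 3 (0.53 log units; beyond the scatter) sets it apart from compound 2. Compound 4 `O=[N+]([O-])c1cc(F)cc(C#Cc2ccccn2)c1` has not been measured. It differs from compound 3 by fluoro in place of bromo on an aromatic carbon. Within the data shown here, no measured step swaps one of these two halogens for the other; compound 1, which also carries fluoro, sits close to compound 3 with a gap within the scatter. A small step is therefore expected, a 1.8-fold higher number from compound 3 to compound 4 (0.25 log units; within the scatter), with little or no loss of potency. Compound 4 is estimated at 0.7 nM, between 0.3 nM and 1.8 nM.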

Compound 4, half-maximal inhibitory concentration: 0.66 nM
Beside the measured number, compound 4's estimate is 1.1-fold (0.03 log units) above it, and the stated range covers the measured number.
By their numbers in this assay, from the lowest: compounds 3, 1, 4 and 2 (each within the scatter of the next, the first and the last beyond it).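

In this assay this position now has a direct swap of one halogen for the other, and a 1.7-fold higher number from compound 3 to compound 4 (0.23 log units; within the scatter) leaves bromo and fluoro indistinguishable here. Cyano also stays within the scatter of fluoro, with a 2.0-fold lower number from compound 2 to compound 4 (0.30 log units; within the scatter) even though a 3.4-fold lower number from compound 2 to compound 3 (0.53 log units; beyond the scatter) separates it from bromo, while among the compounds carrying fluoro a 1.1-fold higher number from compound 1 to compound 4 (0.03 log units; within the scatter) leaves pyridin-2-yl and 2-methyl-1,3-thiazol-4-yl indistinguishable. No supporting data explain these results.

Still open, as far as these compounds go, is whether a methoxy group, an amine or a carboxylic acid on this aromatic carbon would keep the number this low.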